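This account rests on a few compounds, and the source may have more. Where it says the series, first, only, none or still open, it means among the compounds named here.

Measured compounds:
Compound 1 `CO[C@H]1O[C@H](COc2ccc(OC3CCCCC3)cc2)[C@@H](O)[C@H](O)[C@H]1Oc1ccc(OC2CCCCC2)cc1` — in a functional assay on MDA-MB-231 cells (Homo sapiens) for cytotoxicity, read by MTT assay, with a stated time of 48 h (a higher number here means that more compound is needed for the effect, a lower number that less compound is needed), compound 1 gives 20000 nM.
Compound 2 `CO[C@@H]1O[C@H](COc2ccccc2C(C)C)[C@@H](O)[C@H](O)[C@H]1Oc1ccc(OC2CCCCC2)cc1` — in this assay compound 2 gives 44000 nM.
Compound 3 `CO[C@@H]1O[C@H](COc2ccccc2)[C@@H](O)[C@H](O)[C@H]1Oc1ccc(OC2CCCCC2)cc1` — in this assay compound 3 gives "not determined" (no result reported).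

Compound 1 and compound 2 carry the same core and the same aryloxy group on the ring oxygen of the sugar core, differing in the group on the primary position, and their two values sit close to each other. Compound 3 has the unsubstituted phenoxy group at the primary position, and for compound 3 nothing is known in this assay; it stands nowhere on the numbers shown.

Compound 4 `CO[C@@H]1O[C@H](COc2ccc(OC3CCCCC3)cc2)[C@@H](O)[C@H](O)[C@H]1Oc1ccc(OC2CCCCC2)cc1` is the next member. The change from compound 3 to compound 4 is cyclohexyloxy in place of hydrogen on an aromatic carbon. Among the measured compounds shown here, with no number for compound 3, no step can be given for this pair. Compound 4 is the close relative of compound 1, sharing the same set of substituents and differing only in the configuration at the methoxy-bearing carbon. On that basis the value of compound 4 is expected to be near that of compound 1, at 22000 nM with a range of 8000 nM to 60000 nM.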

Compound 4, half-maximal effective concentration: 26000 nM
Beside the measured number, compound 4's estimate is 1.2-fold (0.07 log units) below it, within the range that was stated.
By their numbers in this assay, from the lowest: compounds 1, 4 and 2 (each within the scatter of the next, the first and the last beyond it).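

In this assay the pair shows a 1.3-fold higher number from compound 1 to compound 4 (0.11 log units; within the scatter), so the two drawn configurations at this stereocentre on a saturated ring carbon are not told apart by this read-out. The comparison is clean on one point: the fact that compounds 1 and 4 differ only in the configuration as drawn. The step from hydrogen to cyclohexyloxy on the aromatic carbon cannot be read; compound 3 has no number in this assay.

As far as these compounds go, what cyclohexyloxy contributes at this place therefore stays open, as does whether another group there, such as an amine or a carboxylic acid, would give a number beyond the scatter of compound 4. Also open, from the compounds shown here alone, is whether the configuration at the other stereocentres matters, since only one of them differs between the compounds that can be compared.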